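Pyridinyl dihydropyridine series: chloro for trifluoromethyl

The source may hold more compounds than are shown below. What is called first, only, known or untested is meant among the compounds shown, and "the series" means these compounds.

Compound 1 `CC1=NC(C)=C([N+](=O)[O-])C(c2cccc(C(F)(F)F)n2)/C1=C(/O)OCCc1ccccc1` gives 1410 nM in a functional assay (muscle tissue) with Cavia porcellus as the target; on this read-out lower numbers stand for stronger inhibition and higher numbers for weaker inhibition. For the measured compounds named here, compound 2 `CC1=NC(C)=C([N+](=O)[O-])C(c2ncccc2C(F)(F)F)/C1=C(/O)OCCc1ccccc1` differs only in the pyridinyl group, and the change an at least 42-fold higher number from compound 1 to compound 2 (1.62 log units; beyond the scatter) is the sole measured step in this assay. For compound 2 the recorded value of > 59800 nM is a limit of this assay, not a number (the limit of > 59800 nM in this assay, at which 1 of the 2 values shown sits). Compound 3 `CC1=NC(C)=C([N+](=O)[O-])C(c2cccc(Cl)n2)/C1=C(/O)OCCc1ccccc1` is the next member: 6-chloropyridin-2-yl in place of 3-(trifluoromethyl)pyridin-2-yl on a saturated ring carbon. Compound 3 thus carries 6-chloropyridin-2-yl where compound 1 carries 6-(trifluoromethyl)pyridin-2-yl, so that only the substituent on the pyridine differs between these two. The measured step from compound 1 to compound 2 was large and in the weakening direction; the step to compound 3 reverses that change in the pyridinyl group and is therefore expected to be large in the strengthening direction, an at least 33-fold lower number from compound 2 to compound 3 (1.52 log units; beyond the scatter). Compound 3 is estimated at 1800 nM, within 350 nM to 9000 nM.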

Compound 3, half-maximal inhibitory concentration: 1510 nM
Compound 3: middle estimate off by 1.2-fold (0.08 log units), on the high side; the measured number falls inside the stated range.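

Replacing trifluoromethyl with chloro on the pyridine gives a 1.1-fold higher number from compound 1 to compound 3 (0.03 log units; within the scatter), so this assay does not separate these two substituents in this pair. Going from the 3-(trifluoromethyl)pyridin-2-yl group to the 6-chloropyridin-2-yl group gives an at least 39-fold lower number from compound 2 to compound 3 (1.59 log units; beyond the scatter); this step changes both the substituent and its place on the pyridine, and alongside the previous pair it ties the loss in compound 2 to the 3-(trifluoromethyl)pyridin-2-yl group rather than to trifluoromethyl as such. The value of compound 2 is a limit, not a number: the limit of > 59800 nM in this assay, at which 1 of the 3 values shown sits.

From the compounds shown here alone, whether a 3-chloropyridin-2-yl group would follow the 3-(trifluoromethyl)pyridin-2-yl group stays open. Also open, going by these compounds, is whether a methoxy group or a nitrile in place of chloro on the 6-substituted pyridin-2-yl group would hold the level of compound 3.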